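One Extra Carbon on the Chain: What to Expect

This account rests on a few compounds, and the source may have more. Where it says the series, first, only, none or still open, it means among the compounds named here.

Compound 1, `CC(C(=O)N1CCN(c2ccccc2C(F)(F)F)CC1)N1C(=O)CCC1=O`: 100%
Compound 2, `CC(C(=O)N1CCN(c2cccc(Cl)c2)CC1)N1C(=O)CCC1=O`: 100%
Compound 3, `CCC(C(=O)N1CCOCC1)N1C(=O)CCC1=O`: 0%

In a functional assay on the whole organism (strain Swiss) with Mus musculus as the target, in the maximal electroshock model, with a stated time of 0.5 h, at a dose of 300 mg/kg by the intraperitoneal route (a lower number here means a weaker effect, a higher number a stronger effect of the compound at the dose given), compound 1 gives 100%, level with compound 2 at the digits shown, and together these two are the highest of the three; compound 3 sits far lower, beyond the scatter. Compound 4, `CCC(C(=O)N1CCN(c2ccccc2C(F)(F)F)CC1)N1C(=O)CCC1=O`, has not been measured. It differs from compound 1 in one place: methyl in place of hydrogen on a saturated chain carbon, two bonds along the chain from an amide-type nitrogen in a ring and a carbonyl carbon. Among the compounds with values here, no measured pair isolates this change; compound 3 carries the same longer chain but a different ring on the amide, so its low value cannot be split between the two. A modest fall is expected for the step of a number 20 percentage points lower from compound 1 to compound 4 (beyond the scatter), not beyond the scatter with confidence. Compound 4 is therefore estimated at 80%, with a range from 30% to 100%.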

Compound 4, a percentage reported as activity, at one dose (the size of the read-out at that dose, not a potency): 25%
Compound 4: middle estimate off by 55 percentage points, on the high side, and the stated range ends above it.
By their numbers in this assay, from the lowest: compound 3; then compound 4; then compounds 1 and 2 (each within the scatter of the next).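

In this assay, methyl in place of hydrogen on this saturated chain carbon gives a number 75 percentage points lower from compound 1 to compound 4 (beyond the scatter), a large step for a single added carbon. Within the data shown here, no earlier pair isolated this change, and it now shows that the effect at this dose depends strongly on what this position carries. Nothing available here explains the fall. As far as these compounds go, whether the same change would cost as much on the core of compound 2 remains open. So does the outcome with a longer chain, such as propyl, or with a hydroxymethyl group at this carbon.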